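Branching the Side Chain of Compound 2

The source may report more compounds than this note shows. Statements on the series, on what has been measured and on what is new or still open speak of the compounds shown alone.

In an in vitro ADME assay on microsomes from liver (Rattus norvegicus) for metabolic stability (on this read-out higher numbers stand for a longer-lived compound and lower numbers for a shorter-lived compound), compound 1 `CC(=O)c1cc(C(=O)O)c(Nc2ccc(I)cc2F)n1C` gives 0.117 h and compound 2 `CC(=O)c1cc(C(=O)NOCCCO)c(Nc2ccc(I)cc2F)n1C` gives 0.217 h. These two values lie within the scatter of each other, so compound 2 does not stand apart. Compound 3 `CC(=O)c1cc(C(=O)NOC(CO)CO)c(Nc2ccc(I)cc2F)n1C` differs from compound 2 by 2-hydroxy-1-(hydroxymethyl)ethyl in place of 3-hydroxypropyl on an oxygen. Among the compounds with values here, no measured step covers this exact change. The nearest one, a 1.9-fold higher number from compound 1 to compound 2 (0.27 log units; within the scatter), alters the same side of the molecule, so no shift beyond the scatter is expected in this assay. The expected step is a 1.0-fold lower number from compound 2 to compound 3 (0.01 log units; within the scatter). Compound 3 is estimated at 0.21 h, with an expected range from 0.1 h to 0.43 h.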

Compound 3, half-life: 0.267 h
Compound 3: the middle estimate sits 1.3-fold (0.10 log units) below what was measured; measured number inside the range.
By their numbers in this assay, from the lowest: compounds 1, 2 and 3 (each within the scatter of the next, the first and the last beyond it).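

On the oxygen bound to the amide-type nitrogen, swapping 3-hydroxypropyl for 2-hydroxy-1-(hydroxymethyl)ethyl gives a 1.2-fold higher number from compound 2 to compound 3 (0.09 log units; within the scatter) in this assay, so the two chains cannot be told apart here. Within the data shown here, replacing hydroxy on the carbonyl carbon with (2-hydroxy-1-(hydroxymethyl)ethoxy)amino is the only change so far that passes the scatter, with a 2.3-fold higher number from compound 1 to compound 3 (0.36 log units; beyond the scatter), and the gain is modest. No measurement at hand explains either step. On these data alone, whether a longer chain or an amine-bearing chain on this oxygen would move the number further remains open.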